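The source may report more compounds than this note shows. Statements on the series, on what has been measured and on what is new or still open speak of the compounds shown alone.

Measured compounds:
- compound 1, `Cc1ncc([N+](=O)[O-])n1CCSC(=S)N1CCC(OC(=O)CSC(=S)N2CCCCC2)CC1`: 980 ug/mL
- compound 2, `Cc1ncc([N+](=O)[O-])n1CCSC(=S)N1CCCC(C)C1`: 170 ug/mL
- compound 3, `CCOC(=O)C1CCN(C(=S)SCCn2c([N+](=O)[O-])cnc2C)CC1`: 510 ug/mL

In an ADME assay on HeLa cells (Homo sapiens) for cytotoxicity (a lower number here means a stronger inhibitor, a higher number a weaker inhibitor), compound 1 gives 980 ug/mL, the highest of the three numbers. The nearest number belongs to compound 3, which in this assay gives 510 ug/mL, a gap that lies within the usual scatter, so no order can be drawn between these two. Compound 2 gives 170 ug/mL, and its gap to compound 1 lies beyond the scatter.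

Compound 4, `Cc1ncc([N+](=O)[O-])n1CCSC(=S)N1CCC(OC(=O)CN2CCCCC2)CC1`, is reached from compound 1 by one change: a group of 6 heavy atoms (5 carbon, 1 nitrogen; one six-membered non-aromatic ring with 1 hetero atom) in place of a group of 9 heavy atoms (6 carbon, 1 nitrogen, 2 sulfur; one six-membered non-aromatic ring with 1 hetero atom), on a saturated chain carbon bound to a carbonyl carbon. Going by the values given here, no step between two measured compounds matches this change, so nothing measured tells how large its effect should be. The three numbers span a moderate range, and two of them sit close to compound 1; compound 4 is therefore expected to stay near compound 1, with a 1.4-fold lower number from compound 1 to compound 4 (0.15 log units; within the scatter) expected to fall within or only slightly beyond the scatter. The estimate for compound 4 in this assay is 700 ug/mL, in a range from 250 ug/mL to 1900 ug/mL.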

Compound 4, half-maximal inhibitory concentration: 760 ug/mL
Estimate against measurement, compound 4: 1.1-fold (0.04 log units) below; the measured number falls inside the stated range.
By their numbers in this assay, from the lowest: compound 2; then compounds 3, 4 and 1 (each within the scatter of the next).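

In this assay, piperidin-1-yl in place of the group of 9 heavy atoms, on a saturated chain carbon bound to a carbonyl carbon, gives a 1.3-fold lower number from compound 1 to compound 4 (0.11 log units; within the scatter), so this position tolerates the loss of both sulfur atoms of that group without a readable shift in the number. The second step, (((piperidin-1-yl)methyl)carbonyl)oxy in place of ethoxycarbonyl on a saturated ring carbon, gives a 1.5-fold higher number from compound 3 to compound 4 (0.17 log units; within the scatter), which places these two different substituents on that ring carbon within the scatter of each other as well. No measurement at hand gives a reason for either result.

On these data alone, whether morpholin-4-yl or a dimethylamino group at the same chain carbon would also stay within the scatter remains open. So does the outcome of a carboxylic acid or a hydroxyl group on the saturated ring carbon.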